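The source may report more compounds than this note shows. Statements on the series, on what has been measured and on what is new or still open speak of the compounds shown alone.

Measured in a functional assay on U-373MG ATCC cells (Homo sapiens) for inhibition, read by MTT assay, with a stated time of 72 h; on this read-out higher numbers stand for weaker inhibition and lower numbers for stronger inhibition:

Compound 1 `CCOc1ccc(C2CC2C(=O)NNC(=O)c2ccncc2)cc1` gives 63000 nM.
Compound 2 `COc1ccc(C2CC2C(=O)NNc2nncc3ccccc23)cc1` gives 83000 nM.
Compound 3 `O=C(NNc1nncc2ccccc12)C1CC1c1ccc(OCC(F)(F)F)cc1` gives 25000 nM.

Compound 3 stands lowest of the three numbers, with compound 1 nearest and compound 2 furthest, both separated from it by more than the scatter. For the measured compounds named here, the only step between measured compounds that differ in one place reads a 3.3-fold lower number from compound 2 to compound 3 (0.52 log units; beyond the scatter), a modest movement. Compound 4 `O=C(NNc1nncc2ccccc12)C1CC1c1ccc(OC(F)(F)F)cc1` differs from compound 3 by trifluoromethyl in place of 2,2,2-trifluoroethyl on an oxygen on an aromatic ring. Going by the values given here, no measured step removes a carbon from this chain, so the measured step bears on the question only indirectly: it shows that changing the group on this same oxygen on an aromatic ring shifted the number by a modest amount rather than a large one. The expected step from compound 3 to compound 4 is therefore small, no change at the digits printed from compound 3 to compound 4 (within the scatter), with no clear direction beyond the scatter. Compound 4 is estimated at 25000 nM in this assay, expected to lie between 10000 nM and 60000 nM.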

Compound 4, half-maximal inhibitory concentration: 85000 nM
The estimate for compound 4 lay 3.4-fold (0.53 log units) below the measured number; measured number above the stated range.
By their numbers in this assay, from the lowest: compound 3; then compounds 1, 2 and 4 (each within the scatter of the next).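

In this assay, trifluoromethyl in place of 2,2,2-trifluoroethyl on an oxygen on an aromatic ring gave a 3.4-fold higher number from compound 3 to compound 4 (0.53 log units; beyond the scatter) and so cancelled the earlier gain of a 3.3-fold lower number from compound 2 to compound 3 (0.52 log units; beyond the scatter) at this same oxygen. Trifluoromethyl in place of methyl there gave a 1.0-fold higher number from compound 2 to compound 4 (0.01 log units; within the scatter), so among these three groups only 2,2,2-trifluoroethyl stands apart, and the presence of fluorine alone does not set a compound apart, as compound 4 shows. No measurement at hand explains why the two fluorinated groups differ.

On these data alone, it remains open whether plain ethyl on this oxygen of the shared core would read with methyl or with 2,2,2-trifluoroethyl. Also open, as far as these compounds go, is whether a longer chain, such as 3,3,3-trifluoropropyl, would lower the number further.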